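Acylhydrazide Sulfonamides Against OVCAR-3 Cells: Compound 4 Expected

This account rests on a few compounds, and the source may have more. Where it says the series, first, only, none or still open, it means among the compounds named here.

Compound 1 `Cc1ccccc1NNC(=O)c1cccc(NS(=O)(=O)c2cnc(O)nc2O)c1`: > 20000 nM
Compound 2 `O=C(NNc1ccccc1F)c1ccccc1NS(=O)(=O)c1cnc(O)nc1O`: 9570 nM
Compound 3 `Cc1ccccc1C(=O)NNC(=O)c1ccc(NS(=O)(=O)c2cnc(O)nc2O)cc1`: > 20000 nM

Of the compounds shown here, three on a shared core have been tested in a functional assay on OVCAR-3 cells (Homo sapiens) for antiproliferative activity, read by MTT assay, with a stated time of 24 h; a higher number here means a weaker inhibitor, a lower number a stronger inhibitor. Compound 1 gives only a limit there, > 20000 nM, so no number is known for it. Compound 3 likewise returns only a limit, > 20000 nM. Among the measured compounds shown here, compound 2 is the one compound with a measured number, 9570 nM. Compound 1 therefore stands at the weak end of what is shown, at the limit of > 20000 nM in this assay, at which 2 of the 3 values shown sit, and a value for it cannot be placed beyond that.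

Compound 4 `O=C(NNC(=O)c1cccc(NS(=O)(=O)c2cnc(O)nc2O)c1)c1ccc(F)cc1` is not yet measured. It differs from compound 1 in one place: (4-fluorophenyl)carbonyl in place of 2-methylphenyl on an amine nitrogen. For the measured compounds named here, no step between measured compounds is available to size this change directly. Compound 3, which also carries an aroyl group on that nitrogen, sits at the same limit as compound 1. On that basis the step of a number no higher from compound 1 to compound 4 (the limit leaves the size open) is expected to be small or none beyond the scatter, in either direction. Compound 4 is expected to fall around 20000 nM, with a range from 6000 nM to 60000 nM, and a limit rather than a number is considered likely.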

Compound 4, half-maximal inhibitory concentration: > 20000 nM
Compound 4 ended at the assay's limit (the forecaster's own chance of this, stated with the estimate: 60%); the middle value lies on the limit itself.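

In this assay compound 4 returns > 20000 nM, which is a limit and not a number. Among the compounds shown here, compound 1 also returns only a limit, so no step from compound 1 to compound 4 can be read. The compounds shown leave open whether (4-fluorophenyl)carbonyl in place of 2-methylphenyl changes activity at all, and most values rest on a single point: the limit of > 20000 nM in this assay, at which 3 of the 4 values shown sit.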